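The source may report more compounds than this note shows. Statements on the series, on what has been measured and on what is new or still open speak of the compounds shown alone.

In an ADME assay on HEK-293T cells (Homo sapiens) for cytotoxicity, read by CCK-8 assay, with a stated time of 24 h (a lower number here means that less compound is tolerated, a higher number that more compound is tolerated), three compounds built on a shared core have been measured. Compound 1 `Cn1cc(SCC(=O)NCc2ccc(Cl)c(Cl)c2)c2ccccc21` gives > 100000 nM, which is a limit of the assay and not a number. Compound 2 `O=C(CSc1c[nH]c2ccccc12)NCc1ccccc1` gives > 100000 nM, again a limit and not a number. Within the data shown here, compound 3 `Cn1cc(SCC(=O)N(Cc2ccccc2)Cc2ccccc2)c2ccccc21` gives 91200 nM, and this is the only actual number in the set, so it cannot be ranked firmly against the other two.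

The next compound to be tested is compound 4 `Cn1cc(SCC(=O)NCc2ccccc2)c2ccccc21`. It differs from compound 3 by hydrogen in place of benzyl on an amide-type nitrogen, whose other neighbours are a carbonyl carbon and a saturated chain carbon. Among the measured compounds shown here, no measured pair in the set isolates this change, so any forecast in this assay is indirect. Compound 1 and compound 2 also carry a hydrogen on that nitrogen, and both stand at the limit of > 100000 nM in this assay, at which 2 of the 3 values shown sit. The estimated step of a 1.3-fold higher number from compound 3 to compound 4 (0.10 log units; within the scatter) is therefore expected to be small, towards more compound tolerated, and perhaps no larger than the scatter. A report of compound 4 as a limit alone would not be surprising. For compound 4 the expected value is 115000 nM, with an estimated range from 65000 nM to 220000 nM.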

Compound 4, half-maximal cytotoxic concentration: 95500 nM
Estimate against measurement, compound 4: 1.2-fold (0.08 log units) above; low and high end bracket the measured number.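

In this assay, hydrogen in place of benzyl on the amide-type nitrogen, whose other neighbours are a carbonyl carbon and a saturated chain carbon, now has a measured size: a 1.0-fold higher number from compound 3 to compound 4 (0.02 log units; within the scatter). At this position, then, the presence or absence of the benzyl, with its six-membered aromatic ring, makes no difference beyond the scatter, and compound 4, which carries the amide hydrogen, gives 95500 nM as an actual number rather than a limit. Methyl in place of hydrogen on the aromatic nitrogen gives an at least 1.0-fold lower number from compound 2 to compound 4 (0.01 log units; that floor lies within the scatter), and phenyl in place of 3,4-dichlorophenyl on the saturated chain carbon gives an at least 1.0-fold lower number from compound 1 to compound 4 (0.01 log units; that floor lies within the scatter); each is only a floor, because one end of each step is a limit of the assay and not a number: the limit of > 100000 nM in this assay, at which 2 of the 4 values shown sit.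

As far as these compounds go, the true sizes of those two steps therefore remain unknown. From the compounds shown here alone, it also remains open whether a longer chain, an amine or a carboxylic acid in place of the benzyl on the amide-type nitrogen would produce a step beyond the scatter.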